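The source may hold more compounds than are shown below. What is called first, only, known or untested is meant among the compounds shown, and "the series" means these compounds.

Among the measured compounds shown here, in a functional assay on MCF7 cells (Homo sapiens) for cytotoxicity, read by MTT assay, with a stated time of 72 h (on this read-out lower numbers stand for stronger inhibition and higher numbers for weaker inhibition), compound 1 (`COc1cccc(C=C2C(=O)N(c3ccc(Cl)cc3)N(c3ccc(Cl)cc3)C2=O)c1O`) gives 26700 nM and stands lowest of the two numbers measured so far. Compound 2 (`CC(=C1C(=O)N(c2ccc(Cl)cc2)N(c2ccc(Cl)cc2)C1=O)c1ccc(O)cc1`) gives 76500 nM as the higher number, a gap beyond the usual scatter. For the measured compounds named here, no measured pair differs in one place only. Compound 3 (`O=C1C(=Cc2ccc(F)cc2F)C(=O)N(c2ccc(Cl)cc2)N1c1ccc(Cl)cc1`) keeps the core of compound 1 and carries 2,4-difluorophenyl in place of 2-hydroxy-3-methoxyphenyl on a double-bonded chain carbon bound to a double-bonded ring carbon. Going by the values given here, with no measured step for this change, the expectation rests only on the span of these two numbers. A slightly weaker number is the likelier direction in this assay and the estimated step (a 1.5-fold higher number from compound 1 to compound 3 (0.18 log units; within the scatter)) is not expected to lie clearly beyond the scatter. Compound 3 is estimated at 40000 nM with an expected range from 14000 nM to 100000 nM on this read-out.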

Compound 3, half-maximal inhibitory concentration: 22000 nM
Beside the measured number, compound 3's estimate is 1.8-fold (0.26 log units) above it, within the range that was stated.
By their numbers in this assay, from the lowest: compounds 3 and 1 (each within the scatter of the next); then compound 2.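

In this assay, among the compounds shown here, putting 2,4-difluorophenyl in place of 2-hydroxy-3-methoxyphenyl on a double-bonded chain carbon bound to a double-bonded ring carbon gives a 1.2-fold lower number from compound 1 to compound 3 (0.08 log units; within the scatter), the first step that can be read at this position. The group that enters has 0 hydrogen-bond donors and 0 hydrogen-bond acceptors, whereas the group that leaves has 1 donor and 2 acceptors, yet this read-out does not separate the two compounds of this pair. Nothing at hand offers an explanation for this result.

Going by these compounds, whether a group bearing an amine or a carboxylic acid at this place would also stay within the scatter of compound 1 remains open. On these data alone, it is equally open whether a phenyl group with a single fluorine would do so.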